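Bromo for fluoro: working notes on compounds 2 and 3

This account rests on a few compounds, and the source may have more. Where it says the series, first, only, none or still open, it means among the compounds named here.

Measured so far:
compound 1, `CC(=O)c1ccc(OCc2ccccc2C)cc1`, 77.1 nM in an assay on isolated protein for inhibition of Amine oxidase [flavin-containing] B (Homo sapiens), read by Amplex Red, with a stated time of 15 min; on this read-out lower numbers stand for stronger inhibition and higher numbers for weaker inhibition
compound 2, `CC(=O)c1cccc(OCc2cccc(F)c2)c1`, 193 nM in this assay

Compound 2 stands at the highest of the two numbers recorded. Its nearest neighbour is compound 1, which gives 77.1 nM in this assay; the gap between the two is beyond the scatter of repeated runs, and the two compounds differ in more than one place, so the gap is not tied to any single change.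

Compound 3, `CC(=O)c1cccc(OCc2cccc(Br)c2)c1`, is the next compound to be measured in this assay. It differs from compound 2 in one place only: bromo in place of fluoro on an aromatic carbon, meta to a large group.

Among the measured compounds shown here, no measured pair isolates this change, so there is nothing to anchor its direction. The working expectation is a step of a 1.3-fold lower number from compound 2 to compound 3 (0.11 log units; within the scatter), that is, no movement beyond the usual scatter. Compound 3 is accordingly estimated at 150 nM, with a range from 50 nM to 450 nM.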

Compound 3, half-maximal inhibitory concentration: 96.3 nM
Estimate against measurement, compound 3: 1.6-fold (0.19 log units) above; low and high end bracket the measured number.
By their numbers in this assay, from the lowest: compounds 1, 3 and 2 (each within the scatter of the next, the first and the last beyond it).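

Bromo in place of fluoro on an aromatic carbon, meta to a large group, is the first single change in the series that can be read, and in this assay it gives a 2.0-fold lower number from compound 2 to compound 3 (0.30 log units; within the scatter). Among the compounds shown here, this place therefore accepts either fluoro or bromo without a shift beyond the usual scatter of the read-out, which the earlier compounds could not show, since compound 1 and compound 2 differ in more than one place. Nothing measured here speaks to a reason for this outcome.

The compounds shown carry only these two halogens at this place, so it remains open how the number would respond to a plain hydrogen, an amine, a carboxylic acid or a methoxy group there. Also open, from the compounds shown here alone, is whether the same exchange of fluoro for bromo would read alike on the core of compound 1, since a single pair on one core gives no basis for a wider pattern.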